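The compounds below may be only part of what the source reports. "The series", "measured", "known", "first", "only" and "open" are said of these compounds alone.

Of the compounds shown here, three built on one shared core have been measured in a functional assay for inhibition, with Cavia porcellus as the target; on this read-out higher numbers stand for an effect only at larger amounts of compound and lower numbers for an effect already at smaller amounts. Compound 1 `CCCOC(=O)CCc1cc(CN2CCCC2)c(O)c(CN2CCCC2)c1` gives 7 ug/mL, compound 2 `CC(C)COC(=O)CCc1cc(CN2CCCC2)c(O)c(CN2CCCC2)c1` gives 14 ug/mL, and compound 3 `CCCCOC(=O)CCc1cc(CN2CCCC2)c(O)c(CN2CCCC2)c1` gives 2.5 ug/mL. Compound 3 therefore stands lowest of the three: the step of a 2.8-fold lower number from compound 1 to compound 3 (0.45 log units; beyond the scatter) and the step of a 5.6-fold lower number from compound 2 to compound 3 (0.75 log units; beyond the scatter) both lie beyond the scatter, whereas the step of a 2.0-fold higher number from compound 1 to compound 2 (0.30 log units; within the scatter) does not.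

Compound 4 `O=C(Nc1ccccc1)c1cc(CN2CCCC2)c(O)c(CN2CCCC2)c1` has not yet been measured. It differs from compound 3 by phenylcarbamoyl in place of 2-(butoxycarbonyl)ethyl on an aromatic carbon. Within the data shown here, every measured step so far only reshaped the butoxy or propoxy end of the chain that now leaves entirely, so none of them speaks directly to this exchange; they show only that reworking that chain shifted the read-out by modest amounts. For compound 4 the direction of the step is accordingly open, and a modest move in either direction, a 2.8-fold higher number from compound 3 to compound 4 (0.45 log units; beyond the scatter), is what is expected. Compound 4 is estimated at 7 ug/mL, with a range from 2 ug/mL to 30 ug/mL.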

Compound 4, concentration for half-maximal effect: 11 ug/mL
Compound 4: the middle estimate sits 1.6-fold (0.20 log units) below what was measured; the range from low to high includes it.
By their numbers in this assay, from the lowest: compound 3; then compounds 1, 4 and 2 (each within the scatter of the next).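

At this position, an aromatic carbon para to a hydroxy group, the whole ester chain can be replaced by phenylcarbamoyl and activity persists in this assay, with a 4.4-fold higher number from compound 3 to compound 4 (0.64 log units; beyond the scatter) that lies beyond the scatter. Against the other two esters the same exchange stays within the scatter, at a 1.3-fold lower number from compound 2 to compound 4 (0.10 log units; within the scatter) and a 1.6-fold higher number from compound 1 to compound 4 (0.20 log units; within the scatter), so the earlier changes at the chain end and this change of the entire group give shifts of comparable size. No available evidence explains these differences.

As far as these compounds go, it remains open what a carboxylic acid or a simple methylcarbamoyl would do on this carbon. Also open, from the compounds shown here alone, is whether the phenyl ring or the amide hydrogen of phenylcarbamoyl matters for the read-out.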